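A few compounds are considered here, and "the series" means these few. Any claim that something is new, unique, unknown or untested is made for them only; others in the source may bear on it.

Going by the values given here, only two readings frame this series. In a functional assay on MCF7 cells (Homo sapiens) for antiproliferative activity, read by MTT assay, with a stated time of 72 h (on this read-out lower numbers stand for stronger inhibition and higher numbers for weaker inhibition), compound 1 `O=C1COc2ccc(-c3cnc(Cl)c(NS(=O)(=O)c4ccc(F)cc4)c3)cc2N1C1CCCCC1` gives > 40000 nM, which is a limit of the assay and not a number. Among the compounds with values here, compound 2 `O=C1COc2ccc(-c3cccc(NS(=O)(=O)c4ccc(F)cc4)c3)cc2N1` gives 18300 nM, the only true number available. Compound 3 `O=C1COc2ccc(-c3cccc(NS(=O)(=O)c4ccc(F)cc4)c3)cc2N1c1ccccc1` departs from compound 2 at a single place: phenyl in place of hydrogen on an amide-type nitrogen in a ring. Within the data shown here, no measured pair shows what such a change does in this assay. The expectation is therefore cautious: a 1.4-fold higher number from compound 2 to compound 3 (0.14 log units; within the scatter) is expected to stay within the usual scatter, with any drift towards weaker inhibition. For compound 3 the estimated value is 25000 nM, with an expected range from 8000 nM to 40000 nM.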

Compound 3, half-maximal inhibitory concentration: > 40000 nM
Compound 3 gave a limit, no number; the forecaster's own chance of this, stated with the estimate: 35%; at least 1.6-fold (0.20 log units) between middle value and limit.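

In this assay, going by these compounds alone, phenyl in place of hydrogen on the amide-type nitrogen in a ring brings an at least 2.1-fold higher number from compound 2 to compound 3 (0.33 log units; beyond the scatter), the first step that can be read at this position, and it runs towards weaker inhibition. For compound 3 the reading of > 40000 nM is a limit of the assay and not a number. The step therefore has only a lower bound, and how much weaker compound 3 really is stays unknown because the read-out stops at this ceiling: the limit of > 40000 nM in this assay, at which 2 of the 3 values shown sit.

Going by these compounds, whether methyl, or a chain ending in an amine or a carboxylic acid, on this nitrogen would hold the reading of compound 2 or move it in either direction remains open. Also open, on these data alone, is whether any group at this position can give stronger inhibition than hydrogen does.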